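Methyl on the core of compound 1: an expected step

The compounds below may be only part of what the source reports. "The series", "measured", "known", "first", "only" and "open" are said of these compounds alone.

Measured so far in a functional assay on HT-29 cells (Homo sapiens) for antiproliferative activity, read by MTT assay, with a stated time of 72 h (a higher number here means a weaker inhibitor, a lower number a stronger inhibitor), for two compounds:
Compound 1 `C=CC(=O)Nc1nc(-c2ccccc2)cs1` gives 6600 nM
Compound 2 `C=CC(=O)Nc1nc(-c2ccc(C)cc2)cs1` gives 16100 nM

Compound 1 holds the lower of these two numbers, making it the stronger inhibitor of the pair. The next structure is compound 3 `C=CC(=O)Nc1nc(-c2ccccc2)c(C)s1` and its change from compound 1 is methyl in place of hydrogen on an aromatic carbon with methyl in place of hydrogen on an aromatic carbon, next to the ring sulfur. Going by the values given here, one measured step bears on it, the same exchange at a different place: a 2.4-fold higher number from compound 1 to compound 2 (0.39 log units; beyond the scatter) which is modest. No methyl at the new place has been measured, and a single step sets no rule. A step no larger than that one is therefore expected in this assay towards a higher number, and it may not clear the scatter. The estimated step is a 1.5-fold higher number from compound 1 to compound 3 (0.18 log units; within the scatter) as expected here. The estimate for compound 3 is 10000 nM with an expected range from 4000 nM to 25000 nM for now.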

Compound 3, half-maximal inhibitory concentration: 22000 nM
Beside the measured number, compound 3's estimate is 2.2-fold (0.34 log units) below it, within the range that was stated.
By their numbers in this assay, from the lowest: compound 1; then compounds 2 and 3 (each within the scatter of the next).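

In this assay, methyl in place of hydrogen on the aromatic carbon next to the ring sulfur gives a 3.3-fold higher number from compound 1 to compound 3 (0.52 log units; beyond the scatter) and so shows that this position of the core does not take the exchange without a loss. Together with a 2.4-fold higher number from compound 1 to compound 2 (0.39 log units; beyond the scatter) this means both methyl placements shown move the number upward from compound 1, and neither compound 2 nor compound 3 goes against that direction. No measurement at hand bears on why the number rises at this position.

From the compounds shown here alone, whether a longer chain such as ethyl, or an amine or a carboxylic acid, at this same carbon would also raise the number remains open. Also open, going by these compounds, is whether any group at this place can bring the number below that of compound 1.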